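The compounds below may be only part of what the source reports. "The series", "measured", "known", "first", "only" and "open" are said of these compounds alone.

Compound 1, `COc1ncc(-c2ccc3nc(NC(C)=O)nn3c2)cc1NS(=O)(=O)c1ccc(F)cc1`, gives 850 nM in a functional assay on HCT-116 cells (Homo sapiens) for antiproliferative activity, read by MTT assay, with a stated time of 48 h; a higher number here means a weaker inhibitor, a lower number a stronger inhibitor. Compound 2, `COc1ncc(-c2ccc3nc(N)nn3c2)cc1NS(=O)(=O)c1ccc(F)cc1`, gives 2970 nM. Compound 3, `CCOCCNc1nc2ccc(-c3cnc(OC)c(NS(=O)(=O)c4ccc(F)cc4)c3)cn2n1`, gives 9350 nM.

Compound 3 stands highest of the three in this assay, with a 3.1-fold higher number from compound 2 to compound 3 (0.50 log units; beyond the scatter) and an 11-fold higher number from compound 1 to compound 3 (1.04 log units; beyond the scatter). Compound 4, `CNC(=O)CNc1nc2ccc(-c3cnc(OC)c(NS(=O)(=O)c4ccc(F)cc4)c3)cn2n1`, differs from it by methylcarbamoyl in place of ethoxymethyl on a saturated chain carbon bound to a nitrogen on an aromatic ring. The two measured steps that change what sits on this ring nitrogen both moved the number beyond the scatter, and the lowest value belongs to compound 1, whose substituent on that nitrogen also carries a carbonyl. Going by the values given here, a modest move toward lower numbers is therefore expected, a 2.1-fold lower number from compound 3 to compound 4 (0.32 log units; beyond the scatter), though no measured step shows this exact exchange. Compound 4 is estimated at 4500 nM, within 1500 nM to 13000 nM.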

Compound 4, half-maximal inhibitory concentration: 4910 nM
For compound 4 the middle estimate is 1.1-fold (0.04 log units) below the measured one, within the range that was stated.
By their numbers in this assay, from the lowest: compound 1; then compounds 2, 4 and 3 (each within the scatter of the next, the first and the last beyond it).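

In this assay, methylcarbamoyl in place of ethoxymethyl on this saturated chain carbon gives a 1.9-fold lower number from compound 3 to compound 4 (0.28 log units; within the scatter), and (methylcarbamoyl)methyl in place of hydrogen on the nitrogen gives a 1.7-fold higher number from compound 2 to compound 4 (0.22 log units; within the scatter), so neither change separates the compounds. Against acetyl on that nitrogen, however, the same group gives a 5.8-fold higher number from compound 1 to compound 4 (0.76 log units; beyond the scatter), so a carbonyl somewhere in this substituent does not suffice to match compound 1. No data shown here explain these differences.

From the compounds shown here alone, it remains open whether a longer acyl chain such as propanoyl on the nitrogen would match or pass acetyl. Going by these compounds, the effect of a carboxylic acid or an amine on the saturated chain carbon also remains unknown.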